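The source may hold more compounds than are shown below. What is called first, only, known or untested is meant among the compounds shown, and "the series" means these compounds.

Three compounds share one core. Compound 1 `CCCCCSc1nc(NCc2ccc([Se]C)cc2)c2ccccc2n1` reaches only a limit in a functional assay on CCRF-CEM cells (Homo sapiens) for cytotoxicity, read by MTT assay, with a stated time of 72 h (on this read-out lower numbers stand for stronger inhibition of growth and higher numbers for weaker inhibition of growth), reported as > 100000 nM, which is a limit of the assay and not a number. Compound 2 `CSc1nc(NCc2ccc([Se]C)cc2)c2ccccc2n1` gives 63300 nM in this assay, and compound 3 `C[Se]c1nc(NCc2ccccc2)c2ccccc2n1` gives 39800 nM. Among the two numbers, compound 2 stands highest, with compound 3 nearest and within the scatter. The step of an at least 1.5-fold lower number from compound 1 to compound 2 (0.19 log units; that floor lies within the scatter) rests on the limit of > 100000 nM in this assay, at which 1 of the 3 values shown sits, and concerns the chain on the sulfur, not the ring that changes next.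

Compound 4 `CSc1ccc(CNc2nc(SC)nc3ccccc23)cc1` differs from compound 2 by a group of 2 heavy atoms (1 carbon, 1 sulfur; no ring) in place of a group of 2 heavy atoms (1 carbon, 1 selenium; no ring), on an aromatic carbon. Going by the values given here, no measured step exchanges selenium for sulfur at this place; compound 3 carries its selenium on the core rather than on the ring, so its pair with compound 2 shows only two numbers within the scatter of each other. With nothing pointing to a direction, the step expected in this assay is none beyond the scatter. Compound 4 is therefore estimated at 60000 nM, between 25000 nM and 150000 nM. The expected step is a 1.1-fold lower number from compound 2 to compound 4 (0.02 log units; within the scatter).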

Compound 4, concentration for 50% growth inhibition: > 100000 nM
Compound 4 gave a limit, no number (the forecaster's own chance of this, stated with the estimate: 30%); middle value at least 1.6-fold (0.22 log units) from the limit.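

Going by these compounds alone, this is the first change at the group on the aromatic ring, and in this assay compound 4 reaches only a limit, > 100000 nM, which is not a number. Putting methylsulfanyl in place of the selenium-bearing group gives an at least 1.5-fold higher number from compound 2 to compound 4 (0.19 log units; that floor lies within the scatter), so compound 2 keeps a measured number at this position while its sulfur counterpart does not, yet the floor of the step does not by itself show a real loss. The true size of the step stays unknown, and the reading rests on the limit: the limit of > 100000 nM in this assay, at which 2 of the 4 values shown sit.

The compounds shown leave open how far growth inhibition truly differs between the selenium and sulfur groups at this position. They also leave open what a different group there, such as an amine or a carboxylic acid, would give on the same core.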